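Three Measured Compounds and One Still Awaiting Its Number

The source may hold more compounds than are shown below. What is called first, only, known or untested is meant among the compounds shown, and "the series" means these compounds.

In a functional assay on P388 cells (Mus musculus) for cytotoxicity, read by sulforhodamine B assay (on this read-out lower numbers stand for an effect already at smaller amounts and higher numbers for an effect only at larger amounts of compound), the three measured compounds stand as follows:

compound 1 `C=C1CC[C@@H]2[C@](C)(COC(C)=O)[C@H](OC(C)=O)CC[C@@]2(C)[C@@H]1C/C=C1/C(=O)OC[C@H]1OC(C)=O` gives 1.4 uM
compound 2 `C=C1CC[C@@H]2[C@](C)(CO[Si](C(C)C)(C(C)C)C(C)C)[C@H](OC(C)=O)CC[C@@]2(C)[C@@H]1C/C=C1/C(=O)OC[C@H]1OC(C)=O` gives 1.41 uM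
compound 3 `C=C1CC[C@@H]2[C@](C)(CO[Si](C(C)C)(C(C)C)C(C)C)[C@H](O)CC[C@@]2(C)[C@@H]1C/C=C1/C(=O)OC[C@H]1O` gives 0.88 uM

One structural change is seen twice in this set. Going from compound 2 to compound 1 it is a group of 3 heavy atoms (2 carbon, 1 oxygen; no ring) in place of a group of 10 heavy atoms (9 carbon, 1 silicon; no ring), on an oxygen on a saturated carbon and the step is a 1.0-fold lower number from compound 2 to compound 1 (0.00 log units; within the scatter). Compound 3 shares the core of compound 2 in part, but the difference between the two cores is not broken down here; their values in this assay lie within the scatter of each other.

The unmeasured compound 4 `C=C1CC[C@@H]2[C@](C)(COC(C)=O)[C@H](O)CC[C@@]2(C)[C@@H]1C/C=C1/C(=O)OC[C@H]1O` is related to compound 3 by the same change: a group of 3 heavy atoms (2 carbon, 1 oxygen; no ring) in place of a group of 10 heavy atoms (9 carbon, 1 silicon; no ring), on an oxygen on a saturated carbon. The place of the change is the same in both pairs, word for word.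

Because the earlier step of a 1.0-fold lower number from compound 2 to compound 1 (0.00 log units; within the scatter) stayed within the scatter, the step from compound 3 to compound 4 is expected to be a 1.0-fold higher number from compound 3 to compound 4 (0.01 log units; within the scatter). Compound 4 is therefore estimated to give 0.9 uM in this assay, expected between 0.45 uM and 1.8 uM.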

Compound 4, concentration for half-maximal effect: 2.04 uM
Compound 4: the middle estimate sits 2.3-fold (0.36 log units) below what was measured; measured number above the stated range.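

In this assay, putting acetyl in place of the silicon-containing group on the oxygen gives a 2.3-fold higher number from compound 3 to compound 4 (0.37 log units; beyond the scatter), a modest step that lies beyond the usual scatter for a single pair. Set beside the same change on the other core, however, this step cannot be told apart from the earlier one: the same change on two cores in this assay, a 1.0-fold lower number (0.00 log units; within the scatter) from compound 2 to compound 1 and a 2.3-fold higher number (0.37 log units; beyond the scatter) from compound 3 to compound 4, 2.3-fold (0.37 log units) apart, within the scatter of two such steps. The series therefore gives no firm sign that the core alters what this change does, but two pairs are too few to show that the change carries over unaltered from one core to another.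

The compounds shown leave open how other groups on that same oxygen would read on both cores, such as a free hydroxyl, a methyl ether, a longer acyl chain like butanoyl, or a benzoyl group. They also leave open whether a further pair carrying the same change would read closer to the flat step or to the modest rise.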